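Chain extension at the indazole-bound carbon of the shared core

The compounds below may be only part of what the source reports. "The series", "measured", "known", "first", "only" and "open" are said of these compounds alone.

Measured compounds:
compound 1 `CCCc1nn(-c2nc(N)c3c(n2)NC(=O)C3(C)C)c2ccc(Cl)cc12` — 546000 nM
compound 2 `CCCCc1nn(-c2nc(N)c3c(n2)NC(=O)C3(C)C)c2ccc(Cl)cc12` — 47000 nM

Among the compounds with values here, compound 2 `CCCCc1nn(-c2nc(N)c3c(n2)NC(=O)C3(C)C)c2ccc(Cl)cc12` gives the lowest of the two numbers in an assay on CHO cells for activation of soluble guanylate cyclase alpha1/beta1 complex (Homo sapiens), read by cGMP accumulation; on this read-out higher numbers stand for an effect only at larger amounts of compound and lower numbers for an effect already at smaller amounts; its only neighbour is compound 1 `CCCc1nn(-c2nc(N)c3c(n2)NC(=O)C3(C)C)c2ccc(Cl)cc12`, which in this assay gives 546000 nM against 47000 nM for compound 2, a gap that is a 12-fold lower number from compound 1 to compound 2 (1.07 log units; beyond the scatter) and so lies beyond the scatter.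

Compound 3 `CC1(C)C(=O)Nc2nc(-n3nc(Cc4ccccc4F)c4cc(Cl)ccc43)nc(N)c21` differs from compound 2 by 2-fluorophenyl in place of propyl on a saturated chain carbon bound to an aromatic carbon. Within the data shown here, the only measured step that bears on this change is the one from compound 1 to compound 2, which is a 12-fold lower number from compound 1 to compound 2 (1.07 log units; beyond the scatter): adding a single saturated carbon at the far end of the chain already moved the number well beyond the scatter, downward. The step to compound 3 exchanges the whole remaining chain for a ring and is not directly covered by any measured pair, so the direction rests on that single step alone. Compound 3 is therefore expected to give a lower number than compound 2, with the step estimated at a 12-fold lower number from compound 2 to compound 3 (1.07 log units; beyond the scatter), and its value in this assay is estimated at 4000 nM, within a range of 400 nM to 40000 nM.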

Compound 3, half-maximal effective concentration: 18000 nM
Compound 3: middle estimate off by 4.5-fold (0.65 log units), on the low side, and the stated range covers the measured number.
By their numbers in this assay, from the lowest: compound 3; then compound 2; then compound 1.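

In this assay, the position on a saturated chain carbon bound to an aromatic carbon now proves open to more than chain extension: 2-fluorophenyl in place of propyl gives a 2.6-fold lower number from compound 2 to compound 3 (0.42 log units; beyond the scatter) and stays beyond the scatter. Set against the shorter chain, 2-fluorophenyl in place of ethyl gives a 30-fold lower number from compound 1 to compound 3 (1.48 log units; beyond the scatter) and places the 2-fluorobenzyl compound lowest of the three, so a six-membered aromatic ring at the chain end is tolerated here and the number continues downward past the butyl chain. No supporting measurement bears on what lies behind either step.

The series does not separate the contribution of the ring from that of the fluorine, and a plain benzyl group would be the direct comparison for 2-fluorobenzyl. Also open, from the compounds shown here alone, is whether the downward run continues with a pentyl chain or a longer one, or whether a chain ending in an amine or a carboxylic acid would fit at this position.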